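Returning from Urea to Amide on a Melatonin Ligand

The source may report more compounds than this note shows. Statements on the series, on what has been measured and on what is new or still open speak of the compounds shown alone.

Measured so far:
compound 1 `CCCC(=O)NCCCc1cccc2c1C[C@@H](CCCCc1ccccc1)O2` — 2 nM
compound 2 `CCNC(=O)NCCCc1cccc2c1C[C@@H](CCCCc1ccccc1)O2` — 9 nM

The two compounds share one core and differ only in the group on the carbonyl carbon of the side-chain amide. In an assay on NIH3T3 cells for binding affinity to melatonin receptor type 1A (Homo sapiens) (a higher number here means a weaker inhibitor, a lower number a stronger inhibitor), compound 1 gives 2 nM, and compound 2 gives 9 nM. That leaves compound 2 with the higher of the two numbers, the step of a 4.5-fold higher number from compound 1 to compound 2 (0.65 log units; beyond the scatter) being a modest loss that lies beyond the scatter.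

Compound 3 `O=C(NCCCc1cccc2c1C[C@@H](CCCCc1ccccc1)O2)C1CC1` carries the change (cyclopropyl in place of ethylamino on a carbonyl carbon). This is not yet measured. Within the data shown here, the only step that bears on it is the one from compound 1 to compound 2, where a propyl gave way to an ethylamino and the number rose by a 4.5-fold higher number from compound 1 to compound 2 (0.65 log units; beyond the scatter). The new change goes the other way, removing the ethylamino again and setting a carbon ring in its place, so a return toward the value of compound 1 is expected, with a step of roughly a 3.6-fold lower number from compound 2 to compound 3 (0.56 log units; beyond the scatter) in the direction of a lower number. Compound 3 is therefore estimated at 2.5 nM, within 0.8 nM to 8 nM.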

Compound 3, inhibition constant: 2 nM
The estimate for compound 3 lay 1.3-fold (0.10 log units) above the measured number; measured number inside the range.
By their numbers in this assay, from the lowest: compounds 1 and 3 (each within the scatter of the next); then compound 2.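

In this assay, setting cyclopropyl in place of ethylamino on the carbonyl carbon gives a 4.5-fold lower number from compound 2 to compound 3 (0.65 log units; beyond the scatter), so a carbon ring of the same heavy-atom count fully reverses the modest loss that came with the ethylamino. Against the open propyl chain, the ring shows no change at the digits printed from compound 1 to compound 3 (within the scatter), which means that at this position the three-membered ring and the propyl cannot be told apart in this binding measure, and closing the chain into a ring carries no visible cost; of the three groups, only the ethylamino, the one that brings a nitrogen and a hydrogen-bond donor, stands apart. Nothing available accounts for this pattern or says which feature of the ethylamino goes with the higher number.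

The compounds shown leave open whether larger carbon groups on the carbonyl carbon, such as a cyclobutyl, a cyclohexyl or a longer chain like pentyl, would keep the number as low. They also leave open whether an ethoxy or a methylamino would follow the ethylamino or the carbon groups, which would help separate the role of the nitrogen from that of the chain.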